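The source may hold more compounds than are shown below. What is called first, only, known or untested is meant among the compounds shown, and "the series" means these compounds.

Among the compounds with values here, compound 2 `O=C(OC1CCC(CN2CCN(c3cc(=O)c4cc(C(F)(F)F)cc([N+](=O)[O-])c4s3)CC2)CC1)c1cccs1` is, in an ADME assay on cells (Hepatocyte, Mus musculus) for metabolic stability (on this read-out lower numbers stand for a shorter-lived compound and higher numbers for a longer-lived compound), the only compound with a number: compound 2 gives 0.0867 h. For compound 1 `O=C(OC1CCC(CN2CCN(c3cc(=O)c4cc(C(F)(F)F)cc([N+](=O)[O-])c4s3)CC2)CC1)c1ccco1` the assay reports only a limit, < 0.075 h, which is the floor of the limit of < 0.075 h in this assay, at which 1 of the 2 values shown sits. Within the data shown here, the one measured step, an at least 1.1-fold higher number from compound 1 to compound 2 (0.06 log units; that floor lies within the scatter), lies within the scatter. Compound 3 `CC(=O)OC1CCC(CN2CCN(c3cc(=O)c4cc(C(F)(F)F)cc([N+](=O)[O-])c4s3)CC2)CC1` differs from compound 2 by methyl in place of thiophen-2-yl on a carbonyl carbon. Among the measured compounds shown here, no measured step covers such a change at the ester carbonyl, so compound 3 is expected to keep a short half-life, with a step of a 1.1-fold lower number from compound 2 to compound 3 (0.03 log units; within the scatter) that stays inside the scatter. Compound 3 is estimated at 0.08 h, between 0.04 h and 0.18 h.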

Compound 3, half-life: < 0.15 h
Compound 3 was reported as a limit; the forecaster's own chance of this, stated with the estimate: 40%; the middle value is on the limit's open side.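

Compound 3 is reported only as a limit, < 0.15 h. Within the data shown here, no step from compound 1 or compound 2 to compound 3 can be read from it. As far as these compounds go, whether methyl in place of thiophen-2-yl or furan-2-yl changes the half-life stays open.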